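Compound 4: hydroxy for fluoro on the pendant phenyl

The source may report more compounds than this note shows. Statements on the series, on what has been measured and on what is new or still open speak of the compounds shown alone.

In an assay on mitochondria (strain BALB/c) for inhibition of glycerol-3-phosphate acyltransferase 1, mitochondrial (Mus musculus), read by scintillation counting, with a stated time of 10 min (on this read-out lower numbers stand for stronger inhibition and higher numbers for weaker inhibition), compound 1 `CCCCCCCCS(=O)(=O)Nc1cc(-c2cccc(Cl)c2)ccc1C(=O)O` gives 13800 nM and compound 2 `CCCCCCCCS(=O)(=O)Nc1cc(-c2ccc(OC)cc2)ccc1C(=O)O` gives 13300 nM; the two are separated by a 1.0-fold lower number from compound 1 to compound 2 (0.02 log units; within the scatter). Compound 3 `CCCCCCCCS(=O)(=O)Nc1cc(-c2ccccc2F)ccc1C(=O)O` gives 47200 nM, the highest of the three numbers, standing apart from the others by a 3.4-fold higher number from compound 1 to compound 3 (0.53 log units; beyond the scatter) and by a 3.5-fold higher number from compound 2 to compound 3 (0.55 log units; beyond the scatter). Compound 4 `CCCCCCCCS(=O)(=O)Nc1cc(-c2ccccc2O)ccc1C(=O)O` differs from compound 3 by hydroxy in place of fluoro on an aromatic carbon. Going by the values given here, no measured step exchanges one group for another on the 2-fluorophenyl itself; the two steps that reach compound 3 only show that changing the substituent of this phenyl moves the number by modest amounts. A modest step in either direction is therefore plausible, and none beyond the scatter would not surprise. For compound 4 the expected number is 30000 nM, with a range of 10000 nM to 90000 nM, corresponding to an estimated 1.6-fold lower number from compound 3 to compound 4 (0.20 log units; within the scatter).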

Compound 4, half-maximal inhibitory concentration: 63100 nM
Estimate against measurement, compound 4: 2.1-fold (0.32 log units) below; low and high end bracket the measured number.
By their numbers in this assay, from the lowest: compounds 2 and 1 (each within the scatter of the next); then compounds 3 and 4 (each within the scatter of the next).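

In this assay, going by these compounds alone, the first direct exchange at this place, ortho to a large group, gives a 1.3-fold higher number from compound 3 to compound 4 (0.13 log units; within the scatter), so hydroxy and fluoro are not told apart here despite the added hydrogen-bond donor. The 2-hydroxyphenyl of compound 4 also stands apart from the other two pendant phenyls, with a 4.7-fold higher number from compound 2 to compound 4 (0.68 log units; beyond the scatter) and a 4.6-fold higher number from compound 1 to compound 4 (0.66 log units; beyond the scatter). Nothing available explains these readings.

From the compounds shown here alone, whether the place or the group sets that gap stays open. Going by these compounds, an amine or a methyl at the same place, with no hydroxy or fluoro, remains unknown.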